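Series notes: anilino swap on the bromophenyl-bearing core

The source may report more compounds than this note shows. Statements on the series, on what has been measured and on what is new or still open speak of the compounds shown alone.

Measured so far:
- compound 1, `COc1cc(-c2nc(SCc3cn(CC(=O)NC(=O)Nc4ccccn4)nn3)nc(Nc3cccc(C(F)(F)F)c3)c2C#N)cc(OC)c1OC`, gives 24400 nM in a functional assay on B16-F10 cells (Mus musculus) for inhibition, read by MTT assay, with a stated time of 72 h; on this read-out higher numbers stand for weaker inhibition and lower numbers for stronger inhibition
- compound 2, `Cc1ccc(Nc2nc(SCc3cn(CC(=O)NC(=O)Nc4ccccn4)nn3)nc(-c3ccc(Br)cc3)c2C#N)cc1`, gives 8160 nM in this assay

Compound 2 holds the lower of the two numbers. Compound 1 stands above it, and that gap lies beyond the usual scatter. The two differ in two places at once, in the anilino group and in the aryl group on the shared core, so the numbers alone do not show which of the two changes carries the gap.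

The next compound to be measured is compound 3, `N#Cc1c(Nc2cccc(C(F)(F)F)c2)nc(SCc2cn(CC(=O)NC(=O)Nc3ccccn3)nn2)nc1-c1ccc(Br)cc1`. Against compound 2 the change is 3-(trifluoromethyl)phenyl in place of 4-methylphenyl on a nitrogen on an aromatic ring; the aryl group on the core stays as in compound 2. The same anilino group is present in compound 1, whose 24400 nM is the weaker of the two measured values, but the different aryl group in compound 1 leaves that comparison open.

For compound 3 a step from compound 2 in the direction of weaker inhibition is expected, of moderate size, a 1.6-fold higher number from compound 2 to compound 3 (0.20 log units; within the scatter). The estimate for compound 3 in this assay is 13000 nM, with a range of 5000 nM to 35000 nM.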

Compound 3, half-maximal inhibitory concentration: 4550 nM
Estimate against measurement, compound 3: 2.9-fold (0.46 log units) above, outside the stated range (below it).
By their numbers in this assay, from the lowest: compounds 3 and 2 (each within the scatter of the next); then compound 1.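

In this assay, the step 3-(trifluoromethyl)phenyl in place of 4-methylphenyl on the nitrogen, with the 4-bromophenyl core held constant, gives a 1.8-fold lower number from compound 2 to compound 3 (0.25 log units; within the scatter) and so does not separate these two anilino groups at this position. Within the data shown here, with the 3-(trifluoromethyl)phenyl anilino group held constant, 4-bromophenyl in place of 3,4,5-trimethoxyphenyl on the aromatic carbon gives a 5.4-fold lower number from compound 1 to compound 3 (0.73 log units; beyond the scatter) and is the only single-place step here that lies beyond the scatter, so the aryl group on the core, rather than the anilino group, is where a difference can be read in this pair of compounds. Among these compounds, nothing measured so far bears on the reason for either result.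

Whether the aryl step holds with 4-methylphenyl as the anilino group remains open, since the 3,4,5-trimethoxyphenyl group is shown with only one anilino partner. Also open, going by these compounds, is how the number responds when the anilino ring carries a carboxylic acid or a dimethylamino group, or when the aryl group on the core is a plain phenyl or a 4-chlorophenyl.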